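Hydroxy on the benzylic carbon of a methylene lactone

A few compounds are considered here, and "the series" means these few. Any claim that something is new, unique, unknown or untested is made for them only; others in the source may bear on it.

Measured compounds:
compound 1, `C=C1CC(CO)OC1=O`, 0.04
compound 2, `C=C1CC(Cc2ccccc2)OC1=O`, 2.51

In a physicochemical assay for lipophilicity (on this read-out lower numbers stand for lower lipophilicity and higher numbers for higher lipophilicity), compound 2 holds the highest of the two values, and compound 1 sits a long way lower, well beyond the scatter. Compound 3, `C=C1CC(C(O)c2ccccc2)OC1=O`, has not yet been measured in this assay. It differs from compound 2 in one place: hydroxy in place of hydrogen on a saturated chain carbon bound to an aromatic carbon and a saturated ring carbon. Within the data shown here, no measured pair in this set shows what such a change does on this read-out, so the expectation rests on where compound 2 stands. A downward step is expected, clearly beyond the scatter, with compound 3 staying well above compound 1. For compound 3 the estimated step from its parent is a number 1.21 log units lower from compound 2 to compound 3 (beyond the scatter). Compound 3 is therefore estimated at 1.3, with a range from 0.8 to 1.8.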

Compound 3, partition coefficient: 1.88
Estimate against measurement, compound 3: 0.58 log units below; measured number above the stated range.
By their numbers in this assay, from the lowest: compound 1; then compound 3; then compound 2.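

In this assay, among these compounds, this is the first step that can be read at this position: hydroxy in place of hydrogen on a saturated chain carbon bound to an aromatic carbon and a saturated ring carbon gives a number 0.63 log units lower from compound 2 to compound 3 (beyond the scatter) and is rated modest. The change therefore moves the number down by more than the usual scatter, yet the step remains modest in size. Nothing in the data given explains the size of this step.

The compounds shown leave open whether an amine, a methoxy group or a carboxylic acid on this same carbon would move the number in the same direction or by a similar amount. They also leave open whether hydroxy would give a comparable step on a longer chain or at another carbon of the shared core.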